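This account rests on a few compounds, and the source may have more. Where it says the series, first, only, none or still open, it means among the compounds named here.

In an ADME assay on RAW264.7 cells (Mus musculus) for cytotoxicity, read by MTT assay, with a stated time of 24 h (on this read-out lower numbers stand for higher toxicity in this test and higher numbers for lower toxicity in this test), compound 1 (`CC/C=C\C[C@H]1C(=O)C=C[C@H]1CC(=O)OCCO`) gives 161 uM and stands level with compound 2 (`CC/C=C\C[C@H]1C(=O)C=C[C@H]1CC(=O)OCCOCCOCCO`) at 162 uM and compound 3 (`CC/C=C\C[C@H]1C(=O)C=C[C@H]1CC(=O)OCCOCCOCCOC`) at 163 uM with all three inside the usual scatter. Compound 4 (`CC/C=C\C[C@H]1C(=O)C=C[C@H]1CC(=O)OC1CCCCC1`) has not yet been measured. Its change from compound 1 is cyclohexyl in place of 2-hydroxyethyl on an oxygen next to a carbonyl group. The measured steps bear on this only in part. They show a 1.0-fold higher number from compound 1 to compound 2 (0.00 log units; within the scatter) and a 1.0-fold higher number from compound 1 to compound 3 (0.01 log units; within the scatter) as well as a 1.0-fold higher number from compound 2 to compound 3 (0.00 log units; within the scatter) and each stays within the scatter. Going by these compounds, none of them brings in a six-membered non-aromatic ring of carbon only, so the cyclohexyl group itself remains untested. With the methyl step a 1.0-fold higher number from compound 2 to compound 3 (0.00 log units; within the scatter) as the nearest guide for losing the hydrogen-bond donor, no large move is expected. The expected change is a 1.4-fold lower number from compound 1 to compound 4 (0.15 log units; within the scatter) in this assay and this estimate leans only slightly downward, with no step beyond the scatter firmly foreseen. For compound 4 the estimate is 115 uM with an expected range from 50 uM to 200 uM in this test.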

Compound 4, half-maximal toxic concentration: 31 uM
Estimate against measurement, compound 4: 3.7-fold (0.57 log units) above; the measured number lies below the stated range.
By their numbers in this assay, from the lowest: compound 4; then compounds 1, 2 and 3 (each within the scatter of the next).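

In this assay, among these compounds, the group on an oxygen next to a carbonyl group proved able to move the number: cyclohexyl in place of 2-hydroxyethyl gives a 5.2-fold lower number from compound 1 to compound 4 (0.72 log units; beyond the scatter) and is the only step so far beyond the scatter. The earlier changes at this oxygen, including the methyl-capped chain of compound 3 with no hydrogen-bond donor, left the numbers level, so losing the donor did not by itself go with a drop among those chains. Nothing measured here explains why the cyclohexyl compound stands apart.

The compounds shown leave open whether the ring itself matters or simply the all-carbon group, which a straight hexyl chain on the same oxygen would separate. They also leave open how a cyclopentyl or phenyl ring, or a cyclohexyl ring carrying a hydroxyl or an amine, would read here.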